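Swapping a fluorophenyl sulfone for a cyclopentyl sulfone

This account rests on a few compounds, and the source may have more. Where it says the series, first, only, none or still open, it means among the compounds named here.

Measured so far:
- compound 1, `O=S(=O)(c1ccc(F)cc1)c1cc(Cl)c(O)c2ncccc12`, 0.23 L/kg
- compound 2, `O=S(=O)(c1ccc(F)cc1)c1cc(F)c(O)c2ncccc12`, 3.5 L/kg

Compound 1 gives the lower of the two numbers in an ADME assay on the whole organism for pharmacokinetics, with Rattus norvegicus as the target; a lower number here means that more of the compound stays in the plasma, a higher number that more of the compound sits outside the plasma; its nearest neighbour is compound 2, and the step of a 15-fold higher number from compound 1 to compound 2 (1.18 log units; beyond the scatter) shows how far a single change elsewhere on the shared core can move this read-out. Compound 3, `O=S(=O)(c1cc(Cl)c(O)c2ncccc12)C1CCCC1`, is not yet measured. It differs from compound 1 as follows: cyclopentyl in place of 4-fluorophenyl on a sulfonyl sulfur. For the measured compounds named here, no measured step touches the group on the sulfonyl sulfur, so the one known step offers only a sense of scale, not a direction. The expectation for compound 3 is therefore a modest move at most, a 2.6-fold higher number from compound 1 to compound 3 (0.42 log units; beyond the scatter), with wide uncertainty given how sharply the series has already shifted. Compound 3 is estimated at 0.6 L/kg, within a range of 0.15 L/kg to 2.5 L/kg.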

Compound 3, volume of distribution at steady state: 0.3 L/kg
Compound 3: middle estimate off by 2.0-fold (0.30 log units), on the high side; the measured number falls inside the stated range.
By their numbers in this assay, from the lowest: compounds 1 and 3 (each within the scatter of the next); then compound 2.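

In this assay, for the compounds shown here, the group on the sulfonyl sulfur is the first place where an exchange leaves the two compounds indistinguishable (a 1.3-fold higher number from compound 1 to compound 3 (0.12 log units; within the scatter)), even though an aromatic ring carrying fluorine gives way to a non-aromatic ring of carbon only. The step at the halogen on the core (a 15-fold higher number from compound 1 to compound 2 (1.18 log units; beyond the scatter)) lies beyond the scatter, so among these three compounds only the fluoro for chloro exchange separates the numbers. No measurement at hand bears on the reason for this contrast.

As far as these compounds go, it remains open whether other groups on the sulfonyl sulfur, such as an amine, a carboxylic acid or a longer alkyl chain, would also fall within the scatter of compound 1. From the compounds shown here alone, it is equally open whether cyclopentyl would give the same result on compound 2 (3.5 L/kg).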